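The compounds below may be only part of what the source reports. "The series", "measured", "known", "first", "only" and "open" are said of these compounds alone.

Working notes on the series. Compound 1 `COc1cc(-c2cc(/C=C/C(=O)c3ccc(N)cc3)[nH]n2)cc(OC)c1OC` gives 8320 nM in a functional assay on SK-OV-3 cells (Homo sapiens) for inhibition, read by sulforhodamine B assay, with a stated time of 48 h; a lower number here means a stronger inhibitor of growth, a higher number a weaker inhibitor of growth. Compound 2 `COc1ccc(-c2cc(/C=C/C(=O)c3ccc(N)cc3)[nH]n2)cc1OC` gives 16800 nM in this assay. The change between them, (hydrogen in place of methoxy on an aromatic carbon), gives a 2.0-fold higher number from compound 1 to compound 2 (0.31 log units; beyond the scatter). Compound 3 `COc1cc(C(=O)/C=C/c2cc(-c3cc(OC)c(OC)c(OC)c3)n[nH]2)cc(OC)c1OC` gives 11100 nM in this assay; the difference between the core of compound 3 and the core of compound 1 is not broken down here, and the values of compound 3, compound 1 and compound 2 all lie within the scatter of one another, so no order among them is read.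

Compound 4 `COc1ccc(-c2cc(/C=C/C(=O)c3cc(OC)c(OC)c(OC)c3)[nH]n2)cc1OC` is not yet measured. It differs from compound 3 by hydrogen in place of methoxy on an aromatic carbon, the same change as that from compound 1 to compound 2, made at a place described in the same words. For the measured compounds named here, the expected step is a 2.0-fold higher number from compound 3 to compound 4 (0.30 log units; within the scatter) in this assay, set beside a 2.0-fold higher number from compound 1 to compound 2 (0.31 log units; beyond the scatter), because a 2.0-fold higher number from compound 1 to compound 2 (0.31 log units; beyond the scatter) is the only measured instance of this change and rests on a single pair. Compound 4 is therefore estimated at 22000 nM in this assay, with an expected range from 9000 nM to 55000 nM.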

Compound 4, concentration for total growth inhibition: 19000 nM
The estimate for compound 4 lay 1.2-fold (0.06 log units) above the measured number; the range from low to high includes it.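

In this assay, hydrogen in place of methoxy on an aromatic carbon gives a 1.7-fold higher number from compound 3 to compound 4 (0.23 log units; within the scatter), and the two instances of this change do not differ: the same change on two cores in this assay, a 2.0-fold higher number (0.31 log units; beyond the scatter) from compound 1 to compound 2 and a 1.7-fold higher number (0.23 log units; within the scatter) from compound 3 to compound 4, 1.2-fold (0.07 log units) apart, within the scatter of two such steps

This shows that the change carries from the core of compound 1 to the core of compound 3 with a step of similar size and the same direction, although the new step taken alone lies within the scatter and would not establish an effect by itself. It does not show that the step would hold on any other core or in any other assay, since the reading rests on two pairs and one assay, and it gives no cause for the step.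

The compounds shown leave open what a group other than methoxy or hydrogen at this place, such as hydroxyl, fluorine or a carboxylic acid, would do to the number. They also leave open whether a longer chain on that oxygen, such as ethoxy, would give a step of similar size.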